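Sulfonamide series: ortho-methoxy on the benzyl group

The compounds below may be only part of what the source reports. "The series", "measured", "known", "first", "only" and "open" are said of these compounds alone.

Measured compounds:
compound 1 `CN(CCCNS(=O)(=O)c1cc(C(F)(F)F)cc(C(F)(F)F)c1)Cc1ccccc1`: 28000 nM
compound 2 `O=S(=O)(NCCCNCc1ccccc1)c1cc(C(F)(F)F)cc(C(F)(F)F)c1`: 12000 nM

In a functional assay on BE(2)-C cells (Homo sapiens) for inhibition, read by MTT assay, with a stated time of 72 h (on this read-out lower numbers stand for stronger inhibition of growth and higher numbers for weaker inhibition of growth), compound 1 gives 28000 nM and compound 2 gives 12000 nM. Among the measured compounds shown here, the one step measured so far, a 2.3-fold lower number from compound 1 to compound 2 (0.37 log units; beyond the scatter), is a change on the amine nitrogen and says nothing about the aromatic ring of the benzyl group. For the measured compounds named here, compound 2 stands lowest of the two numbers, with compound 1 as its only neighbour.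

Compound 3 `COc1ccccc1CNCCCNS(=O)(=O)c1cc(C(F)(F)F)cc(C(F)(F)F)c1` differs from compound 2 by methoxy in place of hydrogen on an aromatic carbon. Going by the values given here, no measured step touches this ring, so nothing in the data bears directly on it, and the expectation rests on compound 2 alone. A step of no change at the digits printed from compound 2 to compound 3 (within the scatter) is expected, which is to say none beyond the scatter, in either direction. Compound 3 is therefore estimated at 12000 nM in this assay, with a range of 4000 nM to 36000 nM.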

Compound 3, concentration for 50% growth inhibition: 3600 nM
Estimate against measurement, compound 3: 3.3-fold (0.52 log units) above; the whole stated range lies above it.
By their numbers in this assay, from the lowest: compound 3; then compound 2; then compound 1.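

In this assay, the aromatic ring of the benzyl group responds to substitution: methoxy in place of hydrogen, on an aromatic carbon ortho to a large group, gives a 3.3-fold lower number from compound 2 to compound 3 (0.52 log units; beyond the scatter). With the hydrogen on the amine nitrogen kept as well, the (2-methoxybenzyl)amino group in place of benzyl(methyl)amino gives a 7.8-fold lower number from compound 1 to compound 3 (0.89 log units; beyond the scatter), so the two changes shown at this end of the molecule both lower the number. Nothing available explains why the methoxy group has this effect.

Open, as far as these compounds go, is whether another group at this carbon, such as ethoxy, hydroxyl or a chlorine atom, gives a similar step, and whether methoxy at other ring carbons matches it. Also open, from the compounds shown here alone, is whether the methoxy step carries over to the methyl-bearing amine of compound 1.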